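Replacing carbamoyl with amino in compound 3

This account rests on a few compounds, and the source may have more. Where it says the series, first, only, none or still open, it means among the compounds named here.

Values in an ADME assay on HepG2 cells (Homo sapiens) for cytotoxicity, with a stated time of 72 h; a higher number here means that more compound is needed for the effect, a lower number that less compound is needed:
- compound 1 `COC(=O)c1ccc(NC(=O)Nc2cc(C)nc3ccccc23)cc1`: 20000 nM
- compound 2 `Cc1cc(NC(=O)Nc2ccc(C(N)=O)cc2)c2ccccc2n1`: > 25000 nM (a limit of the assay)
- compound 3 `Cc1cc(NC(=O)Nc2ccc(N)cc2)c2ccccc2n1`: not yet measured

Compound 2 gives > 25000 nM, which is a limit of this assay and not a number. The data show (the limit of > 25000 nM in this assay, at which 1 of the 2 values shown sits). Compound 3 carries amino in place of carbamoyl on an aromatic carbon, para to a large group: amino in place of carbamoyl on an aromatic carbon. Within the data shown here, the one measured step is an at least 1.2-fold higher number from compound 1 to compound 2 (0.09 log units; that floor lies within the scatter), with amino in place of methoxy on a carbonyl carbon. It is a different change and gives no firm size for this one. Among the measured compounds shown here, the expectation therefore leans on compound 1, at 20000 nM, the only true number available. A small downward step is expected, an at least 1.2-fold lower number from compound 2 to compound 3 (0.09 log units; that floor lies within the scatter). For compound 3 the estimated value is 20000 nM, with an expected range of 8000 nM to 40000 nM.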

Compound 3, half-maximal effective concentration: > 25000 nM
Compound 3: only a limit was reported; the forecaster's own chance of this, stated with the estimate: 45%; at least 1.2-fold (0.09 log units) between middle value and limit.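

In this assay, amino in place of methoxycarbonyl on the aromatic carbon gives an at least 1.2-fold higher number from compound 1 to compound 3 (0.09 log units; that floor lies within the scatter). The step from carbamoyl to amino cannot be read, as compound 2 and compound 3 both sit at a limit, so this position has now carried three different groups with no firm change in the number: the limit of > 25000 nM in this assay, at which 2 of the 3 values shown sit. Still open, as far as these compounds go, is whether another group here, such as a carboxylic acid or a longer chain ending in an amine, would give a number clearly apart from these.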